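Adding a second fluoro to the phenylcarbonyl group

The compounds below may be only part of what the source reports. "The series", "measured", "known", "first", "only" and "open" are said of these compounds alone.

Three compounds of the series have numbers in a functional assay on MCF7 cells (Homo sapiens) for antiproliferative activity, read by MTT assay, with a stated time of 72 h; on this read-out higher numbers stand for weaker inhibition and lower numbers for stronger inhibition. Compound 1 `CCN(CC)CCNc1cc(C)c2cc(NC(=O)c3ccc(Cl)c(Cl)c3)ccc2n1` gives 1420 nM; compound 2 `CCN1CCN(c2cc(C)c3cc(NC(=O)c4cccc(F)c4)ccc3n2)CC1` gives 8920 nM; compound 3 `Cc1cc(N2CCCCC2)nc2ccc(NC(=O)c3ccc(Cl)c(Cl)c3)cc12` gives 31100 nM. On these numbers compound 2 stands second highest of the three, above compound 1 and below compound 3, both gaps lying beyond the scatter. Going by the values given here, the only one-place step measured so far is a 22-fold higher number from compound 1 to compound 3 (1.34 log units; beyond the scatter); it changes the amine on the shared core, not the phenylcarbonyl group, so it does not bear on the present change.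

Compound 4 `CCN1CCN(c2cc(C)c3cc(NC(=O)c4ccc(F)c(F)c4)ccc3n2)CC1` differs from compound 2 by fluoro in place of hydrogen on an aromatic carbon, that is, (3-fluorophenyl)carbonyl becomes (3,4-difluorophenyl)carbonyl. Among the compounds with values here, no measured pair in this assay varies the substituents on that ring alone: compounds 1 and 3 carry two chloro groups together with different amines, and compound 2 carries the single fluoro. Within the data shown here, with no measured step to lean on, the expectation for this assay is a step of no size beyond the scatter, in either direction. Compound 4 is therefore estimated at 7500 nM, with a range of 3000 nM to 20000 nM, which means an expected step of a 1.2-fold lower number from compound 2 to compound 4 (0.08 log units; within the scatter).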

Compound 4, half-maximal inhibitory concentration: 5230 nM
Compound 4: the middle estimate sits 1.4-fold (0.16 log units) above what was measured, and the stated range covers the measured number.
By their numbers in this assay, from the lowest: compound 1; then compounds 4 and 2 (each within the scatter of the next); then compound 3.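

In this assay, going by these compounds alone, the first measured one-place step on the phenylcarbonyl group is a 1.7-fold lower number from compound 2 to compound 4 (0.23 log units; within the scatter), so this carbon, ortho to a fluoro group and para to a large group, accepts fluoro in place of hydrogen with no change that can be told from the scatter. Within the data shown here, this is a different picture from the only earlier one-place step, a 22-fold higher number from compound 1 to compound 3 (1.34 log units; beyond the scatter), which lies beyond the scatter and concerns the amine on the shared core, so on these compounds a large difference has been seen at the amine and none at this aromatic carbon. No measured information on the compounds accounts for the size of either step.

The compounds shown leave open how a group other than fluoro, such as methoxy or a nitrile, would read at this same aromatic carbon on the amine carried by compound 2 and compound 4. They also leave open whether fluoro in place of hydrogen here would read the same with the (2-(diethylamino)ethyl)amino group of compound 1 on the shared core.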